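The source may report more compounds than this note shows. Statements on the series, on what has been measured and on what is new or still open speak of the compounds shown alone.

In a functional assay on the whole organism (Tail, strain ICR) with Mus musculus as the target, in the tail flick test, with a stated time of 120 min, at a dose of 25 umol/kg by the oral route (on this read-out lower numbers stand for a weaker effect and higher numbers for a stronger effect at the one dose given), the measured compounds gave:

compound 1 `N=C(N)NCCC[C@H](NC(=O)CN(c1nc(Cl)nc2[nH]cnc12)C1CC1)C(=O)O`: 17%
compound 2 `CC(C)[C@H](NC(=O)CN(c1nc(Cl)nc2[nH]cnc12)C1CC1)C(=O)OCc1ccccc1`: 27.3%
compound 3 `O=C(O)CC[C@H](NC(=O)CN(c1nc(Cl)nc2[nH]cnc12)C1CC1)C(=O)O`: 30.1%

Compound 3 has the highest of the three numbers, but compound 2 lies within the scatter of it; only compound 1 is clearly lower. The next compound, compound 4 `CC(C)[C@H](NC(=O)CN(c1nc(Cl)nc2[nH]cnc12)C1CC1)C(=O)O`, differs from compound 3 by isopropyl in place of 2-carboxyethyl on a saturated chain carbon bound to an amide-type nitrogen and a carbonyl carbon. For the measured compounds named here, the one measured step, a number 13.1 percentage points higher from compound 1 to compound 3 (beyond the scatter), concerns a different position and is modest. Compound 2 already carries the isopropyl, and its value sits within the scatter of compound 3. No step beyond the scatter is therefore expected in this assay. Compound 4 is estimated at 27%, with a range from 12% to 42%. The expected step, a number 3.1 percentage points lower from compound 3 to compound 4 (within the scatter), should stay within the scatter.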

Compound 4, a percentage reported as activity, at one dose (the size of the read-out at that dose, not a potency): 17.1%
Compound 4: the middle estimate sits 9.9 percentage points above what was measured; measured number inside the range.
By their numbers in this assay, from the lowest: compounds 1 and 4 (each within the scatter of the next); then compounds 2 and 3 (each within the scatter of the next).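

In this assay, the chain at this position does count, since isopropyl in place of 2-carboxyethyl gives a clear drop (a number 13 percentage points lower from compound 3 to compound 4 (beyond the scatter)). Isopropyl and the chain of compound 1 stand level (a number 0.1 percentage points higher from compound 1 to compound 4 (within the scatter)), while on the isopropyl compounds the ester position also counts, with hydrogen in place of benzyl (a number 10.2 percentage points lower from compound 2 to compound 4 (beyond the scatter)). No measurement here explains these steps.

Still open, from the compounds shown here alone, is how an amine or a phenyl group on this chain carbon would read. Going by these compounds, a methyl ester in place of the benzyl ester is equally open.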